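Swapping the Sulfonyl Phenyl for a Fused Bicyclic Group

The compounds below may be only part of what the source reports. "The series", "measured", "known", "first", "only" and "open" are said of these compounds alone.

Three measured compounds share one core and differ only in the group joined to the sulfonyl sulfur. Compound 3 `O=C(NCc1ccc(CNS(=O)(=O)c2ccccc2)cc1)c1ccc(CNc2ncccn2)cc1` carries an unsubstituted phenyl there. In an assay on MDA-MB-231 cells for binding affinity to C-X-C chemokine receptor type 4 (Homo sapiens), read by microscopy, with stated times of 10 min and 30 min (a higher number here means that more compound is needed for the effect, a lower number that less compound is needed), compound 3 gives 1 nM. Compound 1 `O=C(NCc1ccc(CNS(=O)(=O)c2cccc(Cl)c2)cc1)c1ccc(CNc2ncccn2)cc1` gives 1 nM in this assay, and no change at the digits printed from compound 1 to compound 3 (within the scatter), so the two stand level at the lowest numbers of the three. Compound 2 `O=C(NCc1ccc(CNS(=O)(=O)c2ccccc2Cl)cc1)c1ccc(CNc2ncccn2)cc1` gives 1000 nM in this assay; a 1000-fold lower number from compound 2 to compound 3 (3.00 log units; beyond the scatter), and a 1000-fold higher number from compound 1 to compound 2 (3.00 log units; beyond the scatter). The ring on the sulfonyl sulfur therefore tolerates one change without effect yet answers another with a very large shift.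

Compound 4 `O=C(NCc1ccc(CNS(=O)(=O)c2ccc3c(c2)CCO3)cc1)c1ccc(CNc2ncccn2)cc1` is the next step from compound 3: a group of 9 heavy atoms (8 carbon, 1 oxygen; one five-membered non-aromatic ring with 1 hetero atom, one six-membered aromatic ring of carbon only) in place of a group of 6 heavy atoms (6 carbon; one six-membered aromatic ring of carbon only), on a sulfonyl sulfur. Going by the values given here, no measured step exchanges the whole phenyl for a larger two-ring group, so the measured steps only bracket the possibilities: one neutral, two very large. The entering group is bulkier and brings an oxygen, which could leave the number where it is or move it sharply upward, as compound 2 shows. On balance, compound 4 is expected to give 10 nM in this assay, within a range from 1 nM to 300 nM. That estimate means an expected step of a 10-fold higher number from compound 3 to compound 4 (1.00 log units; beyond the scatter), with wide uncertainty.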

Compound 4, effective concentration (reported as EC, without a stated level of effect): 1000 nM
The estimate for compound 4 lay 100-fold (2.00 log units) below the measured number; measured number above the stated range.
By their numbers in this assay, from the lowest: compounds 1 and 3 (each within the scatter of the next); then compounds 2 and 4 (each within the scatter of the next).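

In this assay, putting the larger two-ring group on the sulfonyl sulfur in place of the phenyl gives one of the largest steps seen at this position, a 1000-fold higher number from compound 3 to compound 4 (3.00 log units; beyond the scatter), and the comparison with the 3-chlorophenyl compound gives the same size, a 1000-fold higher number from compound 1 to compound 4 (3.00 log units; beyond the scatter). Against the 2-chlorophenyl compound there is no change at the digits printed from compound 2 to compound 4 (within the scatter), so two quite different groups, one carrying a chlorine and one carrying an extra ring and an oxygen, share the same high number, while only the phenyl and 3-chlorophenyl compounds keep the low one. The position is therefore shown to be sensitive to more than a single chlorine placement, but no measurement at hand explains the shared outcome of compound 2 and compound 4.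

The extra ring and the oxygen enter together in compound 4, so the compounds shown cannot tell which of them goes with the step. A phenyl carrying a methoxy group, or the same two-ring group with a carbon in place of its oxygen, would pull the two apart.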